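Moving from compound 2 to compound 3

The source may hold more compounds than are shown below. What is called first, only, known or untested is meant among the compounds shown, and "the series" means these compounds.

Compound 1 `CN1CCCN(CCNc2nccc(-c3c(-c4cccc(O)c4)nc4sccn34)n2)S1(=O)=O`: 12100 nM
Compound 2 `O=S(=O)(NCCCNc1nccc(-c2c(-c3cccc(O)c3)nc3sccn23)n1)c1cccc(F)c1`: 2970 nM

In a functional assay on cells (Panel ovarian (Carcinoma cell lines), Homo sapiens) for inhibition, read by sulforhodamine B assay, with a stated time of 48 h (on this read-out lower numbers stand for stronger inhibition and higher numbers for weaker inhibition), compound 2 holds the lower of the two numbers, 2970 nM. Still unmeasured is compound 3 `O=S(=O)(NCCNc1nccc(-c2c(-c3cccc(O)c3)nc3sccn23)n1)c1ccc(F)cc1`, which carries ((4-fluorophenyl)sulfonyl)amino in place of (((3-fluorophenyl)sulfonyl)amino)methyl, on a saturated chain carbon, two bonds along the chain from a nitrogen on an aromatic ring: ((4-fluorophenyl)sulfonyl)amino in place of (((3-fluorophenyl)sulfonyl)amino)methyl on a saturated chain carbon, two bonds along the chain from a nitrogen on an aromatic ring.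

For the measured compounds named here, only one measured step bears on this change, and only indirectly. Going by the values given here, it is a 4.1-fold lower number from compound 1 to compound 2 (0.61 log units; beyond the scatter), a modest step beyond the scatter, and it exchanged the whole end group, bringing in the aromatic ring of carbon only that compound 3 keeps. Among the compounds with values here, no measured step isolates the shift of the fluorine or the shortening of the chain, so neither direction is favoured in this assay, and no step beyond the scatter is expected. The estimated change is a 1.0-fold higher number from compound 2 to compound 3 (0.00 log units; within the scatter), and the data leave room for a move either way. For compound 3 the expected value is 3000 nM, with an estimated range of 1000 nM to 9000 nM.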

Compound 3, half-maximal inhibitory concentration: 14200 nM
Estimate against measurement, compound 3: 4.7-fold (0.68 log units) below, and the stated range ends below it.
By their numbers in this assay, from the lowest: compound 2; then compounds 1 and 3 (each within the scatter of the next).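

In this assay the saturated chain carbon, two bonds along the chain from a nitrogen on an aromatic ring, proves sensitive to the end group even with the six-membered aromatic ring of carbon only kept: ((4-fluorophenyl)sulfonyl)amino in place of (((3-fluorophenyl)sulfonyl)amino)methyl gives a 4.8-fold higher number from compound 2 to compound 3 (0.68 log units; beyond the scatter) as its step, which cancels the gain of a 4.1-fold lower number from compound 1 to compound 2 (0.61 log units; beyond the scatter) in this series. The fluorophenyl sulfonyl end alone therefore does not secure the lower number of compound 2: a 1.2-fold higher number from compound 1 to compound 3 (0.07 log units; within the scatter) is the step with the six-membered non-aromatic ring with 3 hetero atoms replaced, and it stays within the scatter. No measured evidence here accounts for the size of the swap's effect.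

The swap alters the chain and the fluorine together, and the compounds shown cannot assign the step to either change. ((3-Fluorophenyl)sulfonyl)amino and (((4-fluorophenyl)sulfonyl)amino)methyl at this place would separate the two, while an unsubstituted phenylsulfonyl end would show whether the fluorine matters at all.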